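Ring Nitrogen Substituent and Liver Cell Toxicity

The source may hold more compounds than are shown below. What is called first, only, known or untested is meant among the compounds shown, and "the series" means these compounds.

Compound 1 `Cc1cc(=O)oc2cc(OCc3cn(-c4ccccc4[N+](=O)[O-])nn3)ccc12`: in an ADME assay on Huh-7 cells (Homo sapiens) for cytotoxicity, read by MTT assay, with a stated time of 72 h (on this read-out lower numbers stand for higher toxicity in this test and higher numbers for lower toxicity in this test), compound 1 gives > 100 ug/mL, a limit of the assay.
Compound 2 `Cc1cc(F)ccc1-n1cc(COc2ccc3c(C)cc(=O)oc3c2)nn1`: in this assay compound 2 gives > 100 ug/mL, a limit of the assay.
Compound 3 `Cc1cc(=O)oc2cc(OCc3c[nH]nn3)ccc12`: in this assay compound 3 gives > 100 ug/mL, a limit of the assay.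

Compound 3 therefore stands only at a limit, and it shares that position with both other compounds, since all three sit at the limit of > 100 ug/mL in this assay, at which 3 of the 3 values shown sit. The three steps between them, a step that the two limits leave unreadable from compound 1 to compound 2, a step that the two limits leave unreadable from compound 1 to compound 3 and a step that the two limits leave unreadable from compound 2 to compound 3, cannot be sized, because each end is a limit.

Compound 4 `Cc1cc(=O)oc2cc(OCc3cn(Cc4ccccc4)nn3)ccc12` differs from compound 3 by benzyl in place of hydrogen on an aromatic nitrogen. The measured steps that bear on this change are the two that replace the same hydrogen with an aromatic group, from compound 3 backwards, and both are unreadable. Within the data shown here, no measured step therefore points in any direction, and no movement beyond the scatter is expected in this assay.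

For compound 4 the expected value is 100 ug/mL, with a range from 60 ug/mL to 200 ug/mL. The expected step is a number no higher from compound 3 to compound 4 (the limit leaves the size open), and most likely the assay will again report only a limit.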

Compound 4, half-maximal cytotoxic concentration: > 100 ug/mL
Compound 4: no number, only a limit (the forecaster's own chance of this, stated with the estimate: 85%); the middle value sits exactly at the limit.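

Compound 4 again gives only a limit, so its steps from compound 1, compound 2 and compound 3 cannot be read: the limit of > 100 ug/mL in this assay, at which 4 of the 4 values shown sit.

As far as these compounds go, whether hydrogen, benzyl, 2-nitrophenyl or 4-fluoro-2-methylphenyl on the aromatic nitrogen makes any difference in this assay stays open.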